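The source may hold more compounds than are shown below. What is called first, only, known or untested is meant among the compounds shown, and "the series" means these compounds.

Working notes on the series. In a functional assay on ECa-109 cells for inhibition, with ECa-109 cell line (Homo sapiens) as the target, read by sulforhodamine B assay (on this read-out higher numbers stand for weaker inhibition and lower numbers for stronger inhibition), compound 1 (`O=C1C=C(NC2CCCCC2)C(=O)c2c1nc1n2[C@H]2OC[C@@H](O)[C@H]2OC1`) gives > 16000 nM as a limit and not a number. Among the compounds with values here, compound 2 (`CCOc1ccc(NC2=CC(=O)c3nc4n(c3C2=O)[C@H]2OC[C@@H](O)[C@H]2OC4)cc1`) gives 3210 nM as the only actual number so far in this assay and so has no measured value to be ranked against. Within the data shown here, the one measured step is an at least 4.9-fold lower number from compound 1 to compound 2 (0.69 log units; beyond the scatter) and is only bounded, as the limit of > 16000 nM in this assay, at which 1 of the 2 values shown sits, shows. Compound 3 (`COc1ccc(NC2=CC(=O)c3nc4n(c3C2=O)[C@H]2OC[C@@H](O)[C@H]2OC4)cc1`) differs from compound 2 by hydrogen in place of methyl on a saturated chain carbon bound to an oxygen on an aromatic ring with hydrogen in place of methyl on a saturated chain carbon bound to an oxygen on an aromatic ring, which turns 4-ethoxyphenyl into 4-methoxyphenyl. Among the measured compounds shown here, the measured step replaced the whole group on the amine nitrogen, so it bears only loosely on this far smaller edit, and no measured step alters the ethoxy group alone. No step beyond the scatter is therefore expected in this assay. The estimate stays anchored on compound 2 at 3210 nM as its reference. The expected change is a 1.1-fold lower number from compound 2 to compound 3 (0.03 log units; within the scatter) in this estimate. For compound 3 the estimated value is 3000 nM with an expected range of 1200 nM to 7500 nM in this assay.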

Compound 3, half-maximal inhibitory concentration: > 4000 nM
Compound 3 gave a limit, no number; the forecaster's own chance of this, stated with the estimate: 5%; middle value at least 1.3-fold (0.12 log units) away from the limit.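

In this assay compound 3 gives > 4000 nM, which is a limit of the assay and not a number. The edit from ethoxy to methoxy, the first change shown on a saturated chain carbon bound to an oxygen on an aromatic ring, reads as an at least 1.2-fold higher number from compound 2 to compound 3 (0.09 log units; that floor lies within the scatter), so this step is only a floor and does not establish a real difference between the two compounds. The 4-methoxyphenyl compound therefore gives no evidence that the ethoxy group can be shortened with a measured gain or loss, and the step between compound 1 and compound 3 cannot be read, since both values are limits.

As far as these compounds go, it remains open where the true value of compound 3 lies relative to that of compound 2, and so whether removing the methyl changes the read-out in this assay at all. The compounds shown also leave open how a longer chain such as propoxy, or an amine or a carboxylic acid in place of the ethoxy group, would read on this otherwise unchanged core.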